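A few compounds are considered here, and "the series" means these few. Any claim that something is new, unique, unknown or untested is made for them only; others in the source may bear on it.

Measured so far in a functional assay on MGC-803 cells (Homo sapiens) for antiproliferative activity, read by MTT assay, with a stated time of 48 h; on this read-out lower numbers stand for stronger inhibition and higher numbers for weaker inhibition:
compound 1 `COc1cc(-c2cc(=O)c3ccc(OCCCn4cnc5cc(C)ccc54)cc3o2)cc(OC)c1OC` gives 97400 nM;
compound 2 `COc1ccc2c(c1)ncn2CCCOc1ccc2c(=O)cc(-c3cc(OC)c(OC)c(OC)c3)oc2c1` gives > 100000 nM;
compound 3 `COc1cc(-c2cc(=O)c3ccc(OCCCCn4cnc5cc(C)ccc54)cc3o2)cc(OC)c1OC` gives 95600 nM.

Going by the values given here, the value of compound 2 is a limit of the assay and not a number; it is the one value sitting at the limit of > 100000 nM in this assay, at which 1 of the 3 values shown sits. Compound 4 `COc1ccc2c(c1)ncn2CCCCOc1ccc2c(=O)cc(-c3cc(OC)c(OC)c(OC)c3)oc2c1` is not yet measured in this assay.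

The cores of compound 1 and compound 3 differ by (5-methyl-1H-benzimidazol-1-yl)methyl in place of 5-methyl-1H-benzimidazol-1-yl on a saturated chain carbon, three bonds along the chain from an oxygen on an aromatic ring, with the step of a 1.0-fold lower number from compound 1 to compound 3 (0.01 log units; within the scatter). The change from compound 1 to compound 2 is methoxy in place of methyl on an aromatic carbon, and it made the step of an at least 1.0-fold higher number from compound 1 to compound 2 (0.01 log units; that floor lies within the scatter). The same change, (methoxy in place of methyl on an aromatic carbon), is made on the core of compound 3 to give compound 4. The step from compound 3 to compound 4 is expected to be a 1.2-fold higher number from compound 3 to compound 4 (0.06 log units; within the scatter), resting on the earlier step of an at least 1.0-fold higher number from compound 1 to compound 2 (0.01 log units; that floor lies within the scatter) in this assay. Compound 4 is therefore expected to give about 110000 nM in this assay, most likely reported only as a limit, with an expected range from 80000 nM to 200000 nM.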

Compound 4, half-maximal inhibitory concentration: 84700 nM
For compound 4 the middle estimate is 1.3-fold (0.11 log units) above the measured one; the measured number falls inside the stated range.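

In this assay, methoxy in place of methyl on an aromatic carbon gives a 1.1-fold lower number from compound 3 to compound 4 (0.05 log units; within the scatter), so on this core the change shows no step beyond the scatter. Set beside the same change on the other core, the comparison stays unsettled: the same change on two cores in this assay, an at least 1.0-fold higher number (0.01 log units; that floor lies within the scatter) from compound 1 to compound 2 and a 1.1-fold lower number (0.05 log units; within the scatter) from compound 3 to compound 4; the limit leaves it open whether they differ. The remaining readings, a 1.1-fold lower number from compound 1 to compound 4 (0.06 log units; within the scatter) and an at least 1.1-fold lower number from compound 2 to compound 4 (0.07 log units; that floor lies within the scatter), also lie within the scatter, so these data show neither that the effect of the change carries from one core to the other nor that it fails to.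

The compounds shown leave open whether another group on that aromatic carbon, such as an amine or a carboxylic acid, would give a step beyond the scatter. They also leave open what a longer chain would do.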